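Swapping nitro for methoxy in a series at the limit

A few compounds are considered here, and "the series" means these few. Any claim that something is new, unique, unknown or untested is made for them only; others in the source may bear on it.

Measured in a functional assay on HepG2 cells (Homo sapiens) for inhibition, read by sulforhodamine B assay, with a stated time of 74 h (on this read-out lower numbers stand for stronger inhibition and higher numbers for weaker inhibition), each value being a limit of the assay:
- compound 1 `Cc1ccc(S(=O)(=O)N2C(=O)COC23C=CC(=O)C=C3)cc1`: > 10000 nM
- compound 2 `O=C1C=CC2(C=C1)OCC(=O)N2S(=O)(=O)c1ccccc1`: > 10000 nM
- compound 3 `O=C1C=CC2(C=C1)OCC(=O)N2S(=O)(=O)c1ccc([N+](=O)[O-])cc1`: > 10000 nM

Compound 3 stands at > 10000 nM, which is a limit and not a measured number. Going by the values given here, the series so far comes down to the limit of > 10000 nM in this assay, at which 3 of the 3 values shown sit.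

Compound 4 `COc1ccc(S(=O)(=O)N2C(=O)COC23C=CC(=O)C=C3)cc1` keeps the shared core and changes one group: methoxy in place of nitro on an aromatic carbon. This puts methoxy in place of nitro on an aromatic carbon, para to a large group.

Among the compounds with values here, three measured steps concern this same carbon: a step that the two limits leave unreadable from compound 1 to compound 2, a step that the two limits leave unreadable from compound 1 to compound 3 and a step that the two limits leave unreadable from compound 2 to compound 3. Within the data shown here, none of them has a readable size, and no measured compound carries methoxy. They therefore point in no direction, and no step beyond the scatter can be predicted in this assay. The likeliest result is that compound 4 is again reported only as a limit.

The step expected is a step that the limit leaves unreadable from compound 3 to compound 4. For compound 4 the estimated value is 12000 nM, with an expected range from 4000 nM to 30000 nM.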

Compound 4, half-maximal inhibitory concentration: 1620 nM
Compound 4: the middle estimate sits 7.4-fold (0.87 log units) above what was measured; the whole stated range lies above it.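

In this assay, going by these compounds alone, this aromatic carbon, para to a large group, gives a readable change for the first time. Methoxy in place of nitro gives an at least 6.1-fold lower number from compound 3 to compound 4 (0.79 log units; beyond the scatter), methoxy in place of hydrogen gives an at least 6.1-fold lower number from compound 2 to compound 4 (0.79 log units; beyond the scatter), and methoxy in place of methyl gives an at least 6.1-fold lower number from compound 1 to compound 4 (0.79 log units; beyond the scatter). The steps among compound 1, compound 2 and compound 3 cannot be read, so the group on this carbon can now be seen to matter only through compound 4, the one compound of the four with a measured number rather than a limit: the limit of > 10000 nM in this assay, at which 3 of the 4 values shown sit.

On these data alone, each of these steps has only a lower bound on its size, and how far the true values of compound 1, compound 2 and compound 3 lie beyond their shared limit stays unknown. As far as these compounds go, it also stays open whether methoxy is special at this carbon or whether a hydroxyl, an ethoxy or an amine in the same place would also give a measured number, and whether a longer chain on the oxygen would move the value further in either direction.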